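Second phosphate on a methylamino uridine monophosphate analogue

The source may report more compounds than this note shows. Statements on the series, on what has been measured and on what is new or still open speak of the compounds shown alone.

Measured so far:
compound 1 `CNc1nc(=O)ccn1[C@@H]1O[C@H](COP(=O)(O)O)[C@@H](O)[C@H]1O` — > 100000 nM
compound 2 `O=c1ccn([C@@H]2O[C@H](COP(=O)(O)O)[C@@H](O)[C@H]2O)c(SCc2ccccc2)n1` — >= 100000 nM
compound 3 `COc1nc(=O)ccn1[C@@H]1O[C@H](COP(=O)(O)O)[C@@H](O)[C@H]1O` — 9900 nM

In an in vitro functional assay on 1321-N1 cells for agonist activity at P2Y purinoceptor 2 (Homo sapiens), read by scintillation proximity assay and inositol phosphate accumulation (on this read-out lower numbers stand for an effect already at smaller amounts and higher numbers for an effect only at larger amounts of compound), compound 1 gives > 100000 nM, which is a limit of the assay and not a number. For compound 2 the value >= 100000 nM is likewise a limit. For the measured compounds named here, compound 3 is the only member with a measured number, 9900 nM. Going by the values given here, the change an at least 10-fold lower number from compound 1 to compound 3 (1.00 log units; beyond the scatter) is the one readable step from compound 1, and an at least 10-fold lower number from compound 2 to compound 3 (1.00 log units; beyond the scatter) runs the same way; the step that the two limits leave unreadable from compound 1 to compound 2 cannot be sized because both ends sit at a limit, as the limit of > 100000 nM in this assay, at which 1 of the 3 values shown sits, and the limit of >= 100000 nM in this assay, at which 1 of the 3 values shown sits, show.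

Compound 4 `CNc1nc(=O)ccn1[C@@H]1O[C@H](COP(=O)(O)OP(=O)(O)O)[C@@H](O)[C@H]1O` keeps the whole of compound 1 and changes it only in the phosphate part: a group of 4 heavy atoms (3 oxygen, 1 phosphorus; no ring) in place of a hydrogen atom, on an oxygen. Among the compounds with values here, none of the measured steps concerns this place; all three alter the group on the aromatic carbon of the shared core. The measured steps therefore give no guide to the direction or size of the step from compound 1 to compound 4 in this assay, and compound 1 itself offers only a limit as a starting point.

Compound 4 is expected to reach a number in this assay, estimated at 30000 nM with a range of 3000 nM to 150000 nM. That estimate would mean a step of an at least 3.3-fold lower number from compound 1 to compound 4 (0.52 log units; beyond the scatter), though a limit remains a real possibility.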

Compound 4, half-maximal effective concentration: 7600 nM
Estimate against measurement, compound 4: 3.9-fold (0.60 log units) above; measured number inside the range.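

In this assay, for the compounds shown here, all the earlier steps altered the group on the aromatic carbon of the shared core, whereas this one shows that the phosphate part also moves the read-out while the methylamino group stays in place: an at least 13-fold lower number from compound 1 to compound 4 (1.11 log units; beyond the scatter). With the second phosphate on the oxygen, the methylamino compound gives a measured number, so a group that gave only a limit as the monophosphate does not rule out a measurable effect in this series. The true size of the step remains unknown, since compound 1 stands at a limit and not at a number: the limit of > 100000 nM in this assay, at which 1 of the 4 values shown sits.

The compounds shown leave open whether the same second phosphate would bring a comparable change on the methoxy group of compound 3 or the benzylsulfanyl group of compound 2, as neither of those groups is paired here with a diphosphate. They also leave open whether a third phosphate, or a carboxylic acid in place of the added phosphate, would carry the read-out further in the same direction or lose what the second phosphate gained.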